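Swapping Cyanophenyl for Pyridinyl in a Hedgehog Inhibitor Series

This account rests on a few compounds, and the source may have more. Where it says the series, first, only, none or still open, it means among the compounds named here.

Of the compounds shown here, three sharing one core have been tested in an assay on NIH3T3 cells for inhibition of Sonic hedgehog protein (Mus musculus), read by a luciferase reporter, with a stated time of 48 h; on this read-out higher numbers stand for weaker inhibition and lower numbers for stronger inhibition. Compound 1 `Cc1cnc(Nc2ccc3[nH]ncc3c2)nc1-c1ccc(OC(F)(F)F)cc1` gives 125 nM. Compound 2 `Cc1cnc(Nc2ccc(C(=O)Nc3c(C)cccc3C)cc2)nc1-c1ccc(OC(F)(F)F)c(F)c1` gives 159 nM. Compound 3 `Cc1cnc(Nc2ccc(C(=O)Nc3c(C)cccc3C)cc2)nc1-c1ccc(C#N)cc1` gives 2.8 nM, the lowest of the three numbers, and it stands clearly apart: compound 1 is its nearest neighbour and compound 2 its furthest, both beyond the scatter. Among the measured compounds shown here, the only single-point change measured so far is a 57-fold lower number from compound 2 to compound 3 (1.75 log units; beyond the scatter), a large step.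

Compound 4 `Cc1cnc(Nc2ccc(C(=O)Nc3c(C)cccc3C)cc2)nc1-c1ccncc1` has not yet been measured. It differs from compound 3 in one place: pyridin-4-yl in place of 4-cyanophenyl on an aromatic carbon. For the measured compounds named here, no measured step matches this exact swap. The step that bears on it is a 57-fold lower number from compound 2 to compound 3 (1.75 log units; beyond the scatter), which shows that the group at this position can move the number a long way and that 4-cyanophenyl is the group that gave the lowest number. Pyridin-4-yl keeps one hydrogen-bond acceptor and no donor, but the nitrile is gone.

Compound 4 is therefore expected to give 20 nM, with a range from 4 nM to 100 nM. The step is expected to be a 7.1-fold higher number from compound 3 to compound 4 (0.85 log units; beyond the scatter), a higher number, because a 57-fold lower number from compound 2 to compound 3 (1.75 log units; beyond the scatter) shows how strongly this position responds and compound 3 already holds the best value seen.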

Compound 4, half-maximal inhibitory concentration: 0.54 nM
Compound 4: middle estimate off by 37-fold (1.57 log units), on the high side; the measured number lies below the stated range.
By their numbers in this assay, from the lowest: compound 4; then compound 3; then compounds 1 and 2 (each within the scatter of the next).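

In this assay, pyridin-4-yl in place of 4-cyanophenyl gives a 5.2-fold lower number from compound 3 to compound 4 (0.71 log units; beyond the scatter) and so sets a new low, showing that this position does not need the nitrile, or even the benzene ring that carries it, to reach low numbers. The full span seen at this position is now wider, with a 290-fold lower number from compound 2 to compound 4 (2.47 log units; beyond the scatter) for the change from 3-fluoro-4-(trifluoromethoxy)phenyl, and the group with 6 heavy atoms gives a lower number than the group with 8, although both count 0 hydrogen-bond donors and 1 hydrogen-bond acceptor. No measurement is available to explain why pyridin-4-yl gives the lower number.

Going by these compounds, it remains open whether the ring nitrogen of pyridin-4-yl is what matters here, a question that pyridin-3-yl, plain phenyl or 4-aminophenyl at this position could help to settle. On these data alone, it is also open whether pyridin-4-yl would give a similar gain alongside the other group found in compound 1, which differs from compound 4 in more than one place and so cannot be compared with it directly.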